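Dropping One Chloro from a Dichlorinated Purine-Type Core

The compounds below may be only part of what the source reports. "The series", "measured", "known", "first", "only" and "open" are said of these compounds alone.

Measured so far:
compound 1 `ClCc1cccc(Cn2cnc3nc(Cl)nc(Cl)c32)c1` — 30900 nM
compound 2 `ClCc1ccccc1Cn1cnc2nc(Cl)nc(Cl)c21` — 5240 nM
compound 3 `ClCc1ccc(Cn2cnc3c(Cl)nc(Cl)nc32)cc1` — 30200 nM

In a functional assay on IGROV-1 cells (Homo sapiens) for cytotoxicity, read by sulforhodamine B assay, with a stated time of 48 h (a lower number here means a stronger inhibitor of growth, a higher number a weaker inhibitor of growth), compound 1 gives 30900 nM, the highest of the three numbers. Compound 3 gives 30200 nM, which lies within the scatter of compound 1. Compound 2 gives 5240 nM, a lower number than compound 1 by a margin beyond the scatter; the two differ in more than one place, so only their values can be compared, not a single step.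

Compound 4 `ClCc1cccc(Cn2cnc3ncnc(Cl)c32)c1` has not been measured in this assay. It differs from compound 1 in one place: hydrogen in place of chloro on an aromatic carbon. The chloro that leaves sits between two ring nitrogen atoms of the shared core, the second chloro remaining. For the measured compounds named here, no measured pair isolates this change, so its size is unknown from the data.

The expectation for compound 4 is a number at or above that of compound 1, with the step of a 1.6-fold higher number from compound 1 to compound 4 (0.21 log units; within the scatter) expected to be small and possibly within the scatter. Compound 4 is expected to give about 50000 nM, in the range 15000 nM to 160000 nM.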

Compound 4, concentration for total growth inhibition: 13800 nM
Estimate against measurement, compound 4: 3.6-fold (0.56 log units) above; measured number below the stated range.
By their numbers in this assay, from the lowest: compound 2; then compound 4; then compounds 3 and 1 (each within the scatter of the next).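

In this assay, the chloro between two ring nitrogen atoms of the shared core is not needed for growth inhibition: hydrogen in its place gives a 2.2-fold lower number from compound 1 to compound 4 (0.35 log units; beyond the scatter) and so a modestly stronger inhibitor of growth. This is the first comparison among these compounds that isolates a single change, and it gives this position a measured direction that the differing values of the earlier compounds could not. Nothing given here accounts for the size or direction of this step.

Still open, as far as these compounds go, is whether an amine, a methoxy group or a longer chain at this position would give a lower or a higher number than hydrogen, and whether the chloro remaining in compound 4 can also be replaced. From the compounds shown here alone, it is also open whether hydrogen in place of this chloro would give a similar step in compound 2, the compound with the lowest number so far.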